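A few compounds are considered here, and "the series" means these few. Any claim that something is new, unique, unknown or untested is made for them only; others in the source may bear on it.

Working notes on a small set of anilides on a shared core. Compound 1 `Cc1cccc(NC(=O)C(Cl)Cl)c1` gives "not determined" (no result reported) in a functional assay on Bel-7402 cells (Homo sapiens) for antiproliferative activity, read by MTT assay, with a stated time of 72 h; a lower number here means a stronger inhibitor, a higher number a weaker inhibitor. Compound 2 `O=C(Nc1cccc(I)c1)C(Cl)Cl` gives 5390 nM in this assay. Compound 3 `O=C(Nc1cccc([N+](=O)[O-])c1)C(Cl)Cl` gives 15700 nM in this assay. Among the compounds with values here, only one step with a single change is available among the measured compounds: a 2.9-fold higher number from compound 2 to compound 3 (0.46 log units; beyond the scatter). On the numbers shown, compound 3 therefore stands highest of the two measured values, with compound 2 as its nearest neighbour a modest distance below, and compound 1 contributes no number.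

Compound 4 `O=C(Nc1cccc(C(F)(F)F)c1)C(Cl)Cl` differs from compound 3 in one place: trifluoromethyl in place of nitro on an aromatic carbon. Within the data shown here, no measured step exchanges a nitro for a trifluoromethyl, so the one measured step bears on it only indirectly: it shows that swapping the group at this ring carbon, from iodo to nitro, shifted the number by a modest amount beyond the scatter, nitro giving the higher value. By that comparison, compound 4 is expected to move back toward the lower number, a step of a 2.1-fold lower number from compound 3 to compound 4 (0.32 log units; beyond the scatter) in this assay, though with a single reference step a result within the scatter cannot be ruled out. Compound 4 is accordingly estimated at 7500 nM, with a range from 2500 nM to 22000 nM.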

Compound 4, half-maximal inhibitory concentration: 5970 nM
For compound 4 the middle estimate is 1.3-fold (0.10 log units) above the measured one, and the stated range covers the measured number.
By their numbers in this assay, from the lowest: compounds 2 and 4 (each within the scatter of the next); then compound 3.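

In this assay, this ring carbon now has a second exchange out of nitro, and trifluoromethyl in place of nitro gives a 2.6-fold lower number from compound 3 to compound 4 (0.42 log units; beyond the scatter), so the earlier gap between iodo and nitro is no longer a single comparison. Trifluoromethyl and iodo cannot be separated at this carbon, with a 1.1-fold higher number from compound 2 to compound 4 (0.04 log units; within the scatter), which leaves compound 3 as the one compound among the three with numbers that stands apart from the others, though only by modest steps. The measurements at hand offer no explanation for why nitro separates from the other two groups here.

With compound 1 at "not determined" (no result reported), the methyl group gives no reading on whether the near-equal values of compound 2 and compound 4 extend beyond iodo and trifluoromethyl. Also open, on these data alone, is whether an amine, a carboxylic acid or a longer alkyl chain on this aromatic carbon would group with nitro, with iodo and trifluoromethyl, or apart from both, and whether the same exchanges would behave alike at any other ring carbon of the shared core.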